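One double bond reversed in compound 3

This account rests on a few compounds, and the source may have more. Where it says the series, first, only, none or still open, it means among the compounds named here.

In a functional assay on K562/Adr cells (Homo sapiens) for cytotoxicity, read by sulforhodamine B assay, with a stated time of 48 h (a higher number here means a weaker inhibitor, a lower number a stronger inhibitor), compound 3 (`CN(C)CCn1c(=O)/c(=C/c2ccc(O)cc2)s/c1=C1\C(=O)Nc2ccc(F)cc21`) gives 6140 nM among three measured compounds. Compound 2 (`CCN(CC)CCCn1c(=O)/c(=C/c2ccc(F)c(F)c2)s/c1=C1/C(=O)Nc2ccc(F)cc21`) gives 6480 nM and lies within the scatter of compound 3. Compound 1 (`CCN(CC)CCCn1c(=O)/c(=C/c2cc(OC)c(OC)c(OC)c2)s/c1=C1/C(=O)Nc2ccc(Cl)cc21`) gives 1650 nM and this number is lower than that of compound 3, beyond the scatter. Compound 4 (`CN(C)CCn1c(=O)/c(=C/c2ccc(O)cc2)s/c1=C1/C(=O)Nc2ccc(F)cc21`) departs from compound 3 by one change (the two compounds have the same atoms and bonds and differ only in configuration as drawn: 1 of 2 stereo elements differ; a double bond is drawn Z in compound 3 and E in compound 4) and a double bond is drawn Z in compound 3 and E in compound 4. Within the data shown here, no measured pair isolates such a change, so the expectation rests on compound 3 at 6140 nM and no step beyond the scatter is expected in this assay here. The expected change is a 1.1-fold lower number from compound 3 to compound 4 (0.05 log units; within the scatter) and it stays within the scatter. Compound 4 is estimated at 5500 nM with an expected range from 2500 nM to 12000 nM in this measurement.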

Compound 4, half-maximal inhibitory concentration: 6140 nM
Compound 4: the middle estimate sits 1.1-fold (0.05 log units) below what was measured; the range from low to high includes it.
By their numbers in this assay, from the lowest: compound 1; then compounds 3, 4 and 2 (each within the scatter of the next).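

Among these compounds, compounds 3 and 4 are the first pair here that can be read as a single change, as the earlier compounds differ from one another in several places at once: the fact that compounds 3 and 4 differ only in the configuration as drawn. Reversing this double bond gives no change at the digits printed from compound 3 to compound 4 (within the scatter) in this assay, so this assay does not separate the two drawn configurations in this pair. This is one pair with one set of substituents, and it sets no rule for the others.

From the compounds shown here alone, whether the same reversal would leave the number unmoved on the core of compound 1 stays open. So does the effect of a carboxylic acid in place of the hydroxyl group of compound 4.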